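Swapping the ketone aryl group in a chalcone-like pyrazole series

This account rests on a few compounds, and the source may have more. Where it says the series, first, only, none or still open, it means among the compounds named here.

The measured compounds and their growth-inhibition values:
- compound 1 `COc1cc(-c2cc(/C=C/C(=O)c3ccc(N)cc3)[nH]n2)cc(OC)c1OC`: 2210 nM
- compound 2 `COc1ccc(-c2cc(/C=C/C(=O)c3cc(OC)c(OC)c(OC)c3)[nH]n2)cc1OC`: 1990 nM
- compound 3 `COc1ccc(-c2cc(/C=C/C(=O)c3ccc(N)cc3)[nH]n2)cc1`: 2420 nM

In a functional assay on PC-3 cells (Homo sapiens) for inhibition, read by sulforhodamine B assay, with a stated time of 48 h (a higher number here means a weaker inhibitor of growth, a lower number a stronger inhibitor of growth), compound 1 gives 2210 nM. Among the three numbers this is the second highest, but the spread is small: compound 3 stands nearest to it and compound 2 furthest, and both of those gaps lie within the scatter of the method. So the three measured compounds cannot be told apart on these data; none is the stronger or weaker inhibitor of growth.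

Compound 4 `COc1ccc(C(=O)/C=C/c2cc(-c3cc(OC)c(OC)c(OC)c3)n[nH]2)cc1OC` has not been measured in this assay. It differs from compound 1 in one place: 3,4-dimethoxyphenyl in place of 4-aminophenyl on a carbonyl carbon. For the measured compounds named here, no step between two measured compounds isolates this exact change, so its effect has to be judged from the set as a whole. Compound 2, which also carries methoxy groups on both aryl ends rather than an amino group, gives 1990 nM, a number indistinguishable from that of compound 1.

The step expected from compound 1 to compound 4 is therefore small, a 1.1-fold lower number from compound 1 to compound 4 (0.02 log units; within the scatter), in no preferred direction and not beyond the scatter. Compound 4 is estimated at 2100 nM in this assay, with a range from 900 nM to 5000 nM.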

Compound 4, concentration for 50% growth inhibition: 1360 nM
Compound 4: middle estimate off by 1.5-fold (0.19 log units), on the high side, and the stated range covers the measured number.
By their numbers in this assay, from the lowest: compounds 4, 2, 1 and 3 (each within the scatter of the next).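

In this assay, for the compounds shown here, replacing the 4-aminophenyl group on the carbonyl carbon with 3,4-dimethoxyphenyl gives a 1.6-fold lower number from compound 1 to compound 4 (0.21 log units; within the scatter), the first reading of a change in one place in this set. The step lies within the scatter, so this pair shows that the position can take a group of 10 heavy atoms with no hydrogen-bond donor in place of one of 7 heavy atoms with a hydrogen-bond donor, without a difference in growth inhibition that can be told from the scatter of the method. No measurement offered here bears on the reason for this result.

A single step within the scatter cannot show whether any group on this carbonyl carbon would move the number beyond the scatter, and a plain phenyl group or a 4-hydroxyphenyl group there would test how much of either aryl group matters. Also open, as far as these compounds go, is whether the same exchange on the core of compound 3 would give a step of similar size and direction.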